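A few compounds are considered here, and "the series" means these few. Any claim that something is new, unique, unknown or untested is made for them only; others in the source may bear on it.

Compound 1, `O=C(O)CC[C@H](NC(=O)CN(c1nc(Cl)nc2[nH]cnc12)C1CC1)C(=O)O`: 33.3%
Compound 2, `CC(C)[C@H](NC(=O)CN(c1nc(Cl)nc2[nH]cnc12)C1CC1)C(=O)O`: 38.8%

In a functional assay on the whole organism (Tail, strain ICR) with Mus musculus as the target, in the tail flick test, with a stated time of 60 min, at a dose of 25 umol/kg by the oral route (on this read-out higher numbers stand for a stronger effect at the one dose given and lower numbers for a weaker effect), compound 2 carries the upper of the two numbers shown, though a number 5.5 percentage points higher from compound 1 to compound 2 (within the scatter) leaves that distinction within the scatter. Compound 3, `CC(C)C[C@H](NC(=O)CN(c1nc(Cl)nc2[nH]cnc12)C1CC1)C(=O)O`, differs from compound 2 at the same place: isobutyl in place of isopropyl on a saturated chain carbon bound to an amide-type nitrogen and a carbonyl carbon. For the measured compounds named here, the one measured step that bears on this, the earlier exchange at that carbon, was a number 5.5 percentage points higher from compound 1 to compound 2 (within the scatter), so no step beyond the scatter is expected here either. Compound 3 is therefore estimated at 40%, with a range from 25% to 55%, which means an expected a number 1.2 percentage points higher from compound 2 to compound 3 (within the scatter).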

Compound 3, a percentage reported as activity, at one dose (the size of the read-out at that dose, not a potency): 36.4%
Compound 3: the middle estimate sits 3.6 percentage points above what was measured; the range from low to high includes it.
By their numbers in this assay, from the lowest: compounds 1, 3 and 2 (each within the scatter of the next).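

In this assay the isobutyl group gives a number 2.4 percentage points lower from compound 2 to compound 3 (within the scatter) and, set against compound 1, a number 3.1 percentage points higher from compound 1 to compound 3 (within the scatter), so a third side chain on this saturated chain carbon bound to an amide-type nitrogen and a carbonyl carbon still yields no step beyond the scatter. At this single dose, isopropyl, isobutyl and the side chain of compound 1 cannot be told apart. No evidence at hand accounts for this result.

The compounds shown leave open whether a benzyl group or an amine at this carbon would move the read-out beyond the scatter. They also leave open whether these three compounds would separate at other doses.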